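Second chloro on the aryl group of compound 3

A few compounds are considered here, and "the series" means these few. Any claim that something is new, unique, unknown or untested is made for them only; others in the source may bear on it.

Of the compounds shown here, three of the shared core have been measured. Compound 1 `COc1cccc(/C=C2\CCC/C(=C\c3cccc(OC)c3OC)C2=O)c1` gives 5900 nM in a functional assay on MCF7 cells (Homo sapiens) for cytotoxicity, read by MTT assay, with a stated time of 72 h; on this read-out higher numbers stand for weaker inhibition and lower numbers for stronger inhibition; compound 2 `COc1cccc(/C=C2\CCC/C(=C\c3ccc(O)c(O)c3)C2=O)c1OC` gives 4700 nM; compound 3 `COc1ccc(/C=C2\CCC/C(=C\c3ccc(Cl)cc3)C2=O)cc1OC` gives 6300 nM. The number of compound 3 is the highest of the three, but its gaps to compound 1 and to compound 2 are both within the scatter, so no ranking among them is claimed.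

Compound 4 `COc1ccc(/C=C2\CCC/C(=C\c3ccc(Cl)cc3Cl)C2=O)cc1OC` differs from compound 3 by one change: chloro in place of hydrogen on an aromatic carbon. Among the compounds with values here, the only measured step, a 1.3-fold lower number from compound 1 to compound 2 (0.10 log units; within the scatter), concerns the same position of the core but a different exchange of aryl groups and did not move the number beyond the scatter. Within the data shown here, no measured step adds a chloro to an aryl group, so the new change has no direct precedent here. With only a within-scatter step on record, the expected step is a 1.3-fold lower number from compound 3 to compound 4 (0.10 log units; within the scatter), not beyond the scatter. Compound 4 is therefore estimated at 5000 nM, in a range from 2500 nM to 10000 nM.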

Compound 4, half-maximal inhibitory concentration: 16200 nM
Compound 4: the middle estimate sits 3.2-fold (0.51 log units) below what was measured; measured number outside the range, above it.
By their numbers in this assay, from the lowest: compounds 2, 1 and 3 (each within the scatter of the next); then compound 4.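

In this assay, within the data shown here, the change from 4-chlorophenyl to 2,4-dichlorophenyl gives a 2.6-fold higher number from compound 3 to compound 4 (0.41 log units; beyond the scatter), the only step beyond the scatter, and it runs towards weaker inhibition. One added chloro, ortho to a large group and meta to a chloro group, thus moves the number where the exchange of aryl groups between compound 1 and compound 2 did not, although this rests on a single modest step. No evidence at hand bears on the origin of this step.

Going by these compounds, it remains open whether the step belongs to chloro itself or to any group at this aromatic carbon, and fluoro, methyl or an amine there would separate the two. On these data alone, it is also open whether the same addition would move the number on the aryl groups of compound 1 or compound 2.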